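The compounds below may be only part of what the source reports. "The series", "measured", "known", "first", "only" and "open" are said of these compounds alone.

Measured in a functional assay on BT-474 cells (Homo sapiens) for inhibition, read by fluorescence, with a stated time of 72 h; on this read-out higher numbers stand for weaker inhibition of growth and lower numbers for stronger inhibition of growth:

- Compound 1 `COc1ccc(Nc2nc(N[C@H]3CC[C@H](N)CC3)nc3c2ncn3CCC(C)C)c(OC)c1`: 7900 nM
- Compound 2 `CCCCCCn1cnc2c(Nc3ccc(Cl)cc3)nc(N[C@H]3CC[C@H](N)CC3)nc21`: 5500 nM
- Compound 3 `COc1ccc(Cn2cnc3c(Nc4cccc(Cl)c4)nc(N[C@H]4CC[C@H](N)CC4)nc32)cc1`: 8200 nM

The three values lie within the scatter of one another. Compound 1, at 7900 nM, therefore stands level with the other two, and this assay does not separate any of them. Going by the values given here, no pair among them differs in only one place, so no single structural change has a measured effect here.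

Compound 4 `COc1cc(Nc2nc(N[C@H]3CC[C@H](N)CC3)nc3c2ncn3CCC(C)C)cc(OC)c1` has not yet been measured. It has the same atoms as compound 1, joined differently: 3,5-dimethoxyphenyl in place of 2,4-dimethoxyphenyl on a nitrogen on an aromatic ring. In words, 3,5-dimethoxyphenyl stands in place of 2,4-dimethoxyphenyl on a nitrogen on an aromatic ring, and the rest of the structure is unchanged.

Among the compounds with values here, the only guide is the narrow spread of the measured set. Compound 2 gives 5500 nM and compound 3 gives 8200 nM, although both carry other groups than compound 1 does. On that basis, no change beyond the scatter is expected, and no direction can be favoured with confidence. The estimated change is a 1.2-fold lower number from compound 1 to compound 4 (0.08 log units; within the scatter), which would stay within the scatter. The expected value for compound 4 is 6500 nM, with an estimated range of 2500 nM to 15000 nM.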

Compound 4, concentration for 50% growth inhibition: 5900 nM
Beside the measured number, compound 4's estimate is 1.1-fold (0.04 log units) above it, within the range that was stated.
By their numbers in this assay, from the lowest: compounds 2, 4, 1 and 3 (each within the scatter of the next).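

In this assay, putting 3,5-dimethoxyphenyl in place of 2,4-dimethoxyphenyl on a nitrogen on an aromatic ring gives a 1.3-fold lower number from compound 1 to compound 4 (0.13 log units; within the scatter), so this assay does not separate the two compounds. Going by these compounds alone, the earlier compounds differed from one another in more than one place, whereas this pair offers the first reading of a single change: the same atoms, joined differently at this one group, leave the read-out level within the scatter. Nothing at hand speaks to why this exchange leaves the number level.

The compounds shown leave open whether any group at this position can move the number beyond the scatter, for instance a phenyl ring carrying an amine or a carboxylic acid in place of the two methoxy groups, or an unsubstituted phenyl. They also leave open whether the exchange of 2,4-dimethoxyphenyl for 3,5-dimethoxyphenyl would read the same if the chain on the core were replaced by a longer chain, such as a decyl chain.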